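Replacing 4-methylphenyl with 2-hydroxyethyl on an aromatic carbon

The compounds below may be only part of what the source reports. "The series", "measured", "known", "first", "only" and "open" are said of these compounds alone.

Measured in a functional assay on SW-620 cells (Homo sapiens) for antiproliferative activity, read by MTT assay, with a stated time of 72 h; a lower number here means a stronger inhibitor, a higher number a weaker inhibitor:
Compound 1 `O=C1O[C@H]([C@@H](O)Cn2cc(CNS(=O)(=O)c3ccc(Cl)cc3)nn2)C(OCc2ccccc2)=C1OCc1ccccc1`: 18000 nM
Compound 2 `Cc1ccc(-c2cn(C[C@H](O)[C@H]3OC(=O)C(OCc4ccccc4)=C3OCc3ccccc3)nn2)cc1`: > 100000 nM

Compound 2 stands at > 100000 nM, which is a limit of the assay and not a number. The two results therefore include (the limit of > 100000 nM in this assay, at which 1 of the 2 values shown sits). Compound 3 `O=C1O[C@H]([C@@H](O)Cn2cc(CCO)nn2)C(OCc2ccccc2)=C1OCc1ccccc1` carries 2-hydroxyethyl in place of 4-methylphenyl on an aromatic carbon. Among the compounds with values here, one measured step bears on this change, an at least 5.5-fold higher number from compound 1 to compound 2 (0.74 log units; beyond the scatter), with 4-methylphenyl replacing (((4-chlorophenyl)sulfonyl)amino)methyl on an aromatic carbon. That step shows that changing the group here can move the result in this assay beyond the scatter, but it says nothing direct about 2-hydroxyethyl. A modest move to a lower number is expected, though compound 3 may also remain at the limit. The estimated change is an at least 1.4-fold lower number from compound 2 to compound 3 (0.15 log units; that floor lies within the scatter). Compound 3 is expected at about 70000 nM, with an estimated range of 20000 nM to 200000 nM.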

Compound 3, half-maximal inhibitory concentration: > 100000 nM
Compound 3 gave a limit, no number; the forecaster's own chance of this, stated with the estimate: 45%; at least 1.4-fold (0.15 log units) between middle value and limit.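

In this assay, compound 3 also ends at a limit of the assay and not a number, so 2-hydroxyethyl on this aromatic carbon gives no readable activity, just as 4-methylphenyl did: the limit of > 100000 nM in this assay, at which 2 of the 3 values shown sit. The step between compound 2 and compound 3 cannot be read, so the two groups cannot be ranked. Against the (((4-chlorophenyl)sulfonyl)amino)methyl group, 2-hydroxyethyl gives an at least 5.5-fold higher number from compound 1 to compound 3 (0.74 log units; beyond the scatter), so among these three compounds only compound 1 gives a number, with either a carbon-only aromatic ring or a short hydroxyl-bearing chain in the other two.

Which part of the group in compound 1 matters, the sulfonyl, the amino hydrogen or the 4-chlorophenyl, stays open. So does how a simple aminomethyl group or a carboxylic acid at this position would read.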